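A few compounds are considered here, and "the series" means these few. Any claim that something is new, unique, unknown or untested is made for them only; others in the source may bear on it.

This account follows one structural change in a series of compounds tested in a functional assay on DU-145 cells (Homo sapiens) for inhibition, read by trypan blue exclusion, with a stated time of 72 h; a lower number here means a stronger inhibitor, a higher number a weaker inhibitor. Three members of the series have been measured. Compound 1, with the structure `Cn1c(=O)c(S(=O)(=O)c2ccc(F)cc2[N+](=O)[O-])cc2cnc(Nc3ccc4[nH]ccc4c3)nc21`, gives 1500 nM in this assay. Compound 2, with the structure `O=c1c(S(=O)(=O)c2ccc(F)cc2F)cc2cnc(Nc3ccc4[nH]ccc4c3)nc2n1C1CC1`, gives 500 nM. Compound 3, with the structure `Cn1ccc2cc(Nc3ncc4cc(S(=O)(=O)c5ccc(F)cc5F)c(=O)n(C)c4n3)ccc21`, gives 750 nM. Among these three numbers, compound 1 has the highest. The number of compound 3 lies nearest to it, and the difference between them is within the usual scatter of the assay, so no order between compound 1 and compound 3 can be read from it. The number of compound 2 lies furthest away, and that difference is beyond the scatter, so compound 2 is the stronger inhibitor of the two.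

The step considered here leads from compound 1 to compound 4, whose structure is `Cn1c(=O)c(S(=O)(=O)c2ccc(Cl)cc2Cl)cc2cnc(Nc3ccc4[nH]ccc4c3)nc21`. The change is confined to one place: 2,4-dichlorophenyl in place of 4-fluoro-2-nitrophenyl on a sulfonyl sulfur. The shared core and the rest of the molecule are unchanged.

Going by the values given here, no measured pair shows this exact change, so the expectation rests on the numbers of compounds 2 and 3, which are the other members carrying a differently substituted ring on the sulfonyl sulfur. On that basis a modest step toward a lower number is expected, of size a 2.1-fold lower number from compound 1 to compound 4 (0.33 log units; beyond the scatter). The estimate for compound 4 in this assay is 700 nM, with a likely range from 250 nM to 2000 nM.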

Compound 4, half-maximal inhibitory concentration: 1000 nM
The estimate for compound 4 lay 1.4-fold (0.15 log units) below the measured number; the measured number falls inside the stated range.
By their numbers in this assay, from the lowest: compounds 2, 3, 4 and 1 (each within the scatter of the next, the first and the last beyond it).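

In this assay, putting 2,4-dichlorophenyl in place of 4-fluoro-2-nitrophenyl on the sulfonyl sulfur gives a 1.5-fold lower number from compound 1 to compound 4 (0.18 log units; within the scatter), so no order between these two compounds can be read. Going by these compounds alone, this is the first comparison in which only the ring on the sulfonyl sulfur differs, and it shows that this ring can be exchanged without a change that stands out from the scatter, even though the group that leaves carries hydrogen-bond acceptors and the group that enters carries none. No measurement bearing on the reason for this result is available here.

On these data alone, the exchange replaces both substituents of the ring in a single step, so the separate contributions of the nitro group, the fluorine and the chlorines remain unknown. As far as these compounds go, it also remains open whether a ring bearing an amine or a carboxylic acid on the sulfonyl sulfur, with the rest of compound 1 unchanged, would give a step beyond the scatter.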